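The compounds below may be only part of what the source reports. "The series", "measured", "known", "first", "only" and "open" are said of these compounds alone.

Values in a functional assay on HeLa cells (Homo sapiens), with a stated time of 3 days; a higher number here means a weaker inhibitor, a lower number a stronger inhibitor:

- compound 1 `C=C1[C@H](O)[C@H](O)CO[C@@H]1n1cc(C)c(O)nc1=O`: >= 800000 nM (a limit of the assay, not a number)
- compound 2 `O=C1C=CCO[C@@H]1n1ccc(O)nc1=O`: 42000 nM
- compound 3 `O=C1C=CCO[C@@H]1n1cc(C(F)(F)F)c(O)nc1=O`: 34000 nM

Within the data shown here, compound 3 holds one of only two true numbers, and these two are not separated: the measured step is a 1.2-fold lower number from compound 2 to compound 3 (0.09 log units; within the scatter). Among the measured compounds shown here, the third value is a limit, so it gives no step.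

For the measured compounds named here, compound 4 `Cc1cn([C@H]2OCC=CC2=O)c(=O)nc1O` carries methyl in place of trifluoromethyl on an aromatic carbon, the same aromatic carbon that changes in the one measured step (methyl in place of trifluoromethyl on an aromatic carbon). Compound 1 also carries methyl on an aromatic carbon, but it differs from compound 4 elsewhere as well and offers only a limit, so it sets no size for this change.

Going by the values given here, only one measured step therefore bears on the change, and it replaces hydrogen with trifluoromethyl. Among the compounds with values here, with a 1.2-fold lower number from compound 2 to compound 3 (0.09 log units; within the scatter) as the sole guide, no shift beyond the scatter is expected in this assay on going to methyl, and no direction can be favoured. This rests on a single step, so the range is kept wide.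

The expected step is a 1.1-fold higher number from compound 3 to compound 4 (0.02 log units; within the scatter).

For compound 4 the estimate is 36000 nM, with an expected range of 15000 nM to 85000 nM.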

Compound 4, half-maximal inhibitory concentration: 34000 nM
Compound 4: middle estimate off by 1.1-fold (0.02 log units), on the high side; measured number inside the range.
By their numbers in this assay, from the lowest: compounds 3, 4 and 2 (each within the scatter of the next). At a limit, above all of these: compound 1.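

In this assay this aromatic carbon now has a second one-place change from hydrogen, read as a 1.2-fold lower number from compound 2 to compound 4 (0.09 log units; within the scatter) and joined by the direct exchange of the two larger groups, read as no change at the digits printed from compound 3 to compound 4 (within the scatter). Hydrogen, methyl and trifluoromethyl at this carbon, ortho to a hydroxy group, thus give values within the scatter of each other on the shared core of compounds 2, 3 and 4, which the earlier single step could not show for methyl or for the exchange of trifluoromethyl with methyl. Nothing measured here accounts for this flat result.

As far as these compounds go, whether the flat response holds at this carbon for an amine, a carboxylic acid or a longer chain stays open. Compound 1 gives >= 800000 nM, a limit of the assay and not a number, and it differs from the others in more than one place, so the steps to it cannot be read and the contribution of each difference in its core stays unresolved.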